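A few compounds are considered here, and "the series" means these few. Any claim that something is new, unique, unknown or untested is made for them only; others in the source may bear on it.

Measured compounds:
compound 1 `CS(=O)(=O)Nc1c(O)ccc2c1CCCC2c1c[nH]cn1`: 94%
compound 2 `CC(=O)Nc1cccc2c1CCCC2c1c[nH]cn1`: 35%

Compound 2 stands lowest of the two values measured in a functional assay on spleen with Alpha-1B adrenergic receptor (Rattus norvegicus) as the target; a lower number here means a smaller maximal response, a higher number a larger maximal response. Its nearest neighbour on that scale is compound 1, whose value lies far higher, well beyond the scatter. The two compounds differ in more than one place, so nothing can be said about any single change between them; only the two values themselves are known.

Compound 3 `O=C(Nc1cccc2c1CCCC2c1c[nH]cn1)C(F)(F)F` has not yet been measured. It departs from compound 2 in one place: trifluoromethyl in place of methyl on a carbonyl carbon. For the measured compounds named here, no pair of measured compounds differs by this change alone, so there is no measured step to lean on. Going from compound 2 to compound 3, the expectation is for a small to moderate step in this assay, more likely upward than downward, and quite possibly none beyond the scatter. The estimated step of a number 10 percentage points higher from compound 2 to compound 3 (within the scatter) expresses that reading. For compound 3 the expected value in this assay is 45%, with a range from 15% to 80%.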

Compound 3, largest response reached (reported as efficacy), in percent of the reference or control that the assay uses: 19%
Compound 3: the middle estimate sits 26 percentage points above what was measured; the range from low to high includes it.
By their numbers in this assay, from the lowest: compound 3; then compound 2; then compound 1.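

In this assay, for the compounds shown here, the only change between two compounds that differ in a single place comes out as a number 16 percentage points lower from compound 2 to compound 3 (beyond the scatter) when trifluoromethyl takes the place of methyl on a carbonyl carbon whose other neighbour is an amide-type nitrogen. This shows that the group on this carbonyl carbon is not indifferent to the maximal response: the shift from one carbon to one carbon with three fluorine atoms, with no hydrogen-bond donors or acceptors added by the count, lowers the response by more than the usual scatter and leaves compound 3 lowest of the three, while compound 1 differs from both in more than one place and says nothing about this change. No measurement at hand explains why this step goes downward.

As far as these compounds go, what remains open is whether the fall belongs to the fluorine atoms themselves or would also appear with an ethyl, a tert-butyl or a monofluoromethyl group on the same carbonyl carbon. From the compounds shown here alone, it is equally open how the response would move if the acetamido group of compound 2 gave way to a methanesulfonamido group alone, or to a free amine.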